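The compounds below may be only part of what the source reports. "The series", "measured", "known", "first", "only" and "open" are said of these compounds alone.

In a functional assay on A-431 cells (Homo sapiens) for antiproliferative activity, read by sulforhodamine B assay, with a stated time of 72 h (a higher number here means a weaker inhibitor, a lower number a stronger inhibitor), compound 1 `C=C1CC(CBr)(c2ccccc2)OC1=O` gives 1480 nM. This sits level with compound 2 `C=C1C[C@](CBr)(c2ccccc2)OC1=O` at 1330 nM. Compound 3 `C=C1CC(CBr)(c2cccc(C)c2)OC1=O` gives 4500 nM. Compound 4 `C=C1CC(CBr)(c2ccc(OC)cc2)OC1=O` differs from compound 1 by methoxy in place of hydrogen on an aromatic carbon, which is methoxy in place of hydrogen on an aromatic carbon. The stereo step gives little guidance for this aromatic change: a 1.1-fold lower number from compound 1 to compound 2 (0.05 log units; within the scatter). For the measured compounds named here, the closest precedent is the methyl of compound 3, also placed on an aromatic carbon: a 3.0-fold higher number from compound 1 to compound 3 (0.48 log units; beyond the scatter). It is a single modest step with a different group, so only a weaker inhibitor of similar or smaller size is expected in this assay. The expected change is a 1.9-fold higher number from compound 1 to compound 4 (0.28 log units; within the scatter). For compound 4 the estimate is 2800 nM, with an expected range from 1000 nM to 7500 nM.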

Compound 4, half-maximal inhibitory concentration: 4200 nM
For compound 4 the middle estimate is 1.5-fold (0.18 log units) below the measured one; measured number inside the range.
By their numbers in this assay, from the lowest: compounds 2 and 1 (each within the scatter of the next); then compounds 4 and 3 (each within the scatter of the next).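

Methoxy on an aromatic carbon, para to a group of 9 heavy atoms, gives a 2.8-fold higher number from compound 1 to compound 4 (0.45 log units; beyond the scatter). For the compounds shown here, this is the first substitution at this position of the shared core, and it also makes compound 4 a weaker inhibitor than compound 1. Alongside a 3.0-fold higher number from compound 1 to compound 3 (0.48 log units; beyond the scatter), both aromatic substitutions shown move in the same direction, and no compound shown goes against this. No measured property here bears on the origin of the methoxy step. Open, going by these compounds, is how an amine, a carboxylic acid or a chlorine atom on the same aromatic carbon would read, and whether any group there gives a stronger inhibitor than compound 1.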